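Amide-terminus acid swap in the shared core series

This account rests on a few compounds, and the source may have more. Where it says the series, first, only, none or still open, it means among the compounds named here.

Measured so far in an assay on isolated protein for agonist activity at Bile acid receptor (Homo sapiens), read by FRET; on this read-out lower numbers stand for smaller maximal responses and higher numbers for larger maximal responses:

compound 1, `CS(=O)(=O)NC(=O)c1ccc(C2CC2c2ccc(OCc3c(-c4c(Cl)cccc4Cl)noc3C3CC3)cc2Cl)cc1`: 100%
compound 2, `O=C(O)CNC(=O)c1ccc(C2CC2c2ccc(OCc3c(-c4c(Cl)cccc4Cl)noc3C3CC3)cc2Cl)cc1`: 100%
compound 3, `O=C(O)c1cccc([C@H]2C[C@](OCCO)(c3ccc(OCc4c(-c5c(Cl)cccc5Cl)noc4C4CC4)cc3Cl)C2)c1`: 97%

Compound 2 gives the same number as compound 1, and the gap between either of them and compound 3 is within the scatter, so on these three numbers compound 2 sits at the common level of the series rather than apart from it.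

The unmeasured compound 4, `O=C(NCCS(=O)(=O)O)c1ccc(C2CC2c2ccc(OCc3c(-c4c(Cl)cccc4Cl)noc3C3CC3)cc2Cl)cc1`, differs from compound 2 in one place: sulfomethyl in place of carboxy on a saturated chain carbon bound to an amide-type nitrogen. Within the data shown here, the only measured step that bears on this position is the one at the amide-type nitrogen, no change at the digits printed from compound 1 to compound 2 (within the scatter), which was within the scatter although it exchanged a methylsulfonyl for a carboxymethyl. Among the measured compounds shown here, no measured step shows a carboxy to sulfomethyl exchange itself, and compound 3 changes elsewhere, so it gives no separate guidance. For the measured compounds named here, with the one relevant step flat, no step beyond the scatter is expected for compound 4, and no change at the digits printed from compound 2 to compound 4 (within the scatter) is the estimated change. Compound 4 is therefore expected to give 100% in this assay, with a range from 90% to 108%.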

Compound 4, largest response reached (reported as efficacy), in percent of the reference or control that the assay uses: 98%
Compound 4: middle estimate off by 2 percentage points, on the high side, and the stated range covers the measured number.
By their numbers in this assay, from the lowest: compounds 3, 4, 1 and 2 (each within the scatter of the next).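

The exchange of carboxy for sulfomethyl on a saturated chain carbon bound to an amide-type nitrogen gives a number 2 percentage points lower from compound 2 to compound 4 (within the scatter) in this assay and extends the flat result at this position to a second exchange. Replacing methylsulfonyl with 2-sulfoethyl on the amide-type nitrogen gives a number 2 percentage points lower from compound 1 to compound 4 (within the scatter) and closes the set of direct comparisons among these three termini on the shared core. Methylsulfonyl, carboxymethyl and 2-sulfoethyl therefore read alike here, and no measurement is available to explain this.

On these data alone, an amine, a tetrazole or a longer chain such as 3-sulfopropyl on the amide-type nitrogen remains open. The read-out of this assay gives only the largest response, so any difference among these compounds in the concentration needed to reach it also remains open.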